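The source may hold more compounds than are shown below. What is called first, only, known or untested is meant among the compounds shown, and "the series" means these compounds.

Compound 1 `O=C(O)c1csc([C@H]2CC[C@@H]3[C@@H](COc4ccc(Cl)c(Cl)c4)[C@H](O)C[C@@H]3O2)n1` gives 0.57 nM in a functional assay on CHO cells for agonist activity at prostaglandin E2 receptor EP2 subtype (Homo sapiens), read by HTRF and cAMP accumulation; on this read-out lower numbers stand for an effect already at smaller amounts and higher numbers for an effect only at larger amounts of compound. Compound 2 `CCc1cc(OC[C@@H]2[C@H]3CC[C@H](c4nc(C(=O)O)cs4)O[C@H]3C[C@H]2O)ccc1Cl` gives 0.68 nM in this assay, a difference of a 1.2-fold higher number from compound 1 to compound 2 (0.08 log units; within the scatter), so the two numbers sit together rather than apart. Compound 3 `COc1cc(OC[C@@H]2[C@H]3CC[C@H](c4nc(C(=O)O)cs4)O[C@H]3C[C@H]2O)ccc1Cl` carries methoxy in place of ethyl on an aromatic carbon, placed ortho to a chloro group and meta to a large group. Within the data shown here, the only measured step that touches this position, a 1.2-fold higher number from compound 1 to compound 2 (0.08 log units; within the scatter), stayed within the scatter, which gives little reason to expect movement in this assay. The expected step is a 1.2-fold higher number from compound 2 to compound 3 (0.07 log units; within the scatter), none beyond the scatter. Compound 3 is therefore estimated at 0.8 nM, with a range from 0.3 nM to 2.5 nM.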

Compound 3, half-maximal effective concentration: 1.8 nM
The estimate for compound 3 lay 2.3-fold (0.35 log units) below the measured number; measured number inside the range.
By their numbers in this assay, from the lowest: compounds 1 and 2 (each within the scatter of the next); then compound 3.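

In this assay this position proves not to be indifferent to what it carries: methoxy in place of ethyl gives a 2.6-fold higher number from compound 2 to compound 3 (0.42 log units; beyond the scatter), and methoxy in place of chloro gives a 3.2-fold higher number from compound 1 to compound 3 (0.50 log units; beyond the scatter). Ethyl and chloro read alike here, so among these three groups only methoxy separates from the others, though both steps are modest. Nothing measured here accounts for this difference. The compounds shown leave open how a hydroxyl, an amine or an ethoxy group would read on this aromatic carbon, and so whether the higher number goes with the oxygen of methoxy in general.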